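Furan-2-yl for 2,5-difluorophenyl at the sulfur-adjacent ring carbon

The source may hold more compounds than are shown below. What is called first, only, known or untested is meant among the compounds shown, and "the series" means these compounds.

Compound 1 `CC(C)(C)Cc1c(-c2cc(F)ccc2F)sc(N)c1C(=O)c1ccc(Cl)cc1` gives 1% in an assay on CHO cells for displacement of a labelled ligand from adenosine receptor A3 (Homo sapiens), read by scintillation counting, tested at 10 uM (on this read-out higher numbers stand for more inhibition at the one concentration tested (going by the name of the read-out) and lower numbers for less inhibition), level with compound 2 `CC(C)(C)Cc1c(-c2ccccc2)sc(N)c1C(=O)c1ccccc1Cl` at 1% and compound 3 `CC(C)(C)Cc1c(-c2ccccc2)sc(N)c1C(=O)c1ccc(Cl)cc1Cl` at 1%. Going by the values given here, the single measured step, no change at the digits printed from compound 2 to compound 3 (within the scatter), stays within the scatter, and it concerns the carbonyl-bearing aryl, not the ring position changed here. Compound 4 `CC(C)(C)Cc1c(-c2ccco2)sc(N)c1C(=O)c1ccc(Cl)cc1` differs from compound 1 by furan-2-yl in place of 2,5-difluorophenyl on an aromatic carbon. Among the compounds with values here, no measured step touches this position, so the only guide is that every compound measured so far sits near the floor of this assay. Compound 4 is therefore expected to remain near that floor, with a number 2 percentage points higher from compound 1 to compound 4 (within the scatter) expected to fall within the scatter. The estimate for compound 4 is 3%, with a range from -5% to 15%.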

Compound 4, a percentage reported as inhibition, at one concentration (the size of the read-out at that concentration, not a potency): 1%
Compound 4: the middle estimate sits 2 percentage points above what was measured, and the stated range covers the measured number.
By their numbers in this assay, from the lowest: compounds 1, 2, 3 and 4 (each within the scatter of the next).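

In this assay the ring carbon next to the ring sulfur now has a measured step, and furan-2-yl in place of 2,5-difluorophenyl gives no change at the digits printed from compound 1 to compound 4 (within the scatter) at this position. A five-membered aromatic ring with an oxygen and a six-membered all-carbon aromatic ring therefore read the same here. Nothing measured bears on the reason for this flat result.

Whether an amine, a carboxylic acid or a longer chain at this position would leave the level of these compounds remains open. From the compounds shown here alone, with all four compounds level, the role of this position in the read-out also remains open.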